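The source may hold more compounds than are shown below. What is called first, only, known or untested is meant among the compounds shown, and "the series" means these compounds.

Compound 2 `CCCCCCCCCCCCCCCOC(=O)CCC(=O)N1CCN(CCCOc2cc3c(Nc4ccc(F)c(Cl)c4)ncnc3cc2OC)CC1` stands at the top of the two numbers available in a functional assay on A549 cells (Homo sapiens) for cytotoxicity, read by MTT assay, with a stated time of 24 h, tested at 40 uM; on this read-out lower numbers stand for a stronger effect and higher numbers for a weaker effect at the one concentration tested. In this assay, going by the values given here, compound 2 gives 85.5%, and its only neighbour, compound 1 `CCCCCCCCCCCOC(=O)CCC(=O)N1CCN(CCCOc2cc3c(Nc4ccc(F)c(Cl)c4)ncnc3cc2OC)CC1`, gives 12% in this assay. Among the compounds with values here, the one measured step that bears on the question is a number 73.5 percentage points higher from compound 1 to compound 2 (beyond the scatter), a large rise that came from lengthening the same saturated chain.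

Compound 3 `CCCCCCCCCCCCCCCCCOC(=O)CCC(=O)N1CCN(CCCOc2cc3c(Nc4ccc(F)c(Cl)c4)ncnc3cc2OC)CC1` is made from compound 2 by ethyl in place of hydrogen on a saturated chain carbon, ten or more bonds along the chain from an oxygen next to a carbonyl group. This is the same kind of change as the measured step, at the same place on the chain, but it is a shorter extension, and compound 2 already sits close to the weak end of what this read-out can show. On that basis the expected step of a number 4.5 percentage points higher from compound 2 to compound 3 (within the scatter) is a small rise or no change beyond the usual scatter. Compound 3 is therefore estimated to give 90% in this assay, with a range from 75% to 100%. Whether the measured number falls there is what the next part will tell.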

Compound 3, a percentage reported as activity, at one concentration (the size of the read-out at that concentration, not a potency): 85.2%
Compound 3: middle estimate off by 4.8 percentage points, on the high side; low and high end bracket the measured number.
By their numbers in this assay, from the lowest: compound 1; then compounds 3 and 2 (each within the scatter of the next).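

Adding ethyl at this place on the saturated chain gives no step that can be told from the scatter in this assay (a number 0.3 percentage points lower from compound 2 to compound 3 (within the scatter)), so the large rise seen earlier does not go on in the same way when the chain grows further. Hexyl in place of hydrogen, counted from compound 1, gives a step about as large as the butyl step (a number 73.2 percentage points higher from compound 1 to compound 3 (beyond the scatter)), so among these three compounds, compound 1 stands apart, while compound 2 and compound 3 read alike, and the length of the chain matters here only up to a point that lies somewhere at or before the chain of compound 2. The data offer no measured reason for this behaviour.

The compounds shown leave open where along the way from the chain of compound 1 to the chain of compound 2 the large step happens, which a chain of intermediate length would settle. They also leave open how a shorter chain, or a chain ending in a carboxylic acid or an amine, would read in this assay.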